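Diaryl ether series on the shared pyrrolidine acetic acid core

A few compounds are considered here, and "the series" means these few. Any claim that something is new, unique, unknown or untested is made for them only; others in the source may bear on it.

Measured so far:
Compound 1, `Cc1ccccc1Cc1ccc(N2C[C@@H](C(F)(F)F)C[C@H]2CC(=O)O)cc1`: 710 nM
Compound 2, `COc1ccc(Oc2ccc(N3C[C@@H](C(F)(F)F)C[C@H]3CC(=O)O)cc2)c(C)c1`: 170 nM

Both compounds were run in a functional assay on cells for agonist activity at Free fatty acid receptor 1 (Mus musculus), read by FLIPR and calcium flux, with a stated time of 100 s; a higher number here means that more compound is needed for the effect, a lower number that less compound is needed. Compound 2 holds the lowest number of the two; its nearest neighbour, compound 1, sits at a gap beyond the usual scatter, so compound 2 is the stronger of the pair on these numbers.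

The next compound, compound 3, `Cc1cccc(Oc2ccc(N3C[C@@H](C(F)(F)F)C[C@H]3CC(=O)O)cc2)c1C`, keeps the core of compound 2 and the ether link and changes only the outer ring: 2,3-dimethylphenyl in place of 4-methoxy-2-methylphenyl on an oxygen on an aromatic ring. For the measured compounds named here, no pair of measured compounds isolates this change, so no measured step can be quoted for it. The expectation rests on compound 2 alone, with its value of 170 nM as the anchor. The step from compound 2 to compound 3 is expected to be small, a 1.5-fold higher number from compound 2 to compound 3 (0.17 log units; within the scatter), with no clear direction beyond the scatter. Compound 3 is estimated at 250 nM, in the range 100 nM to 700 nM.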

Compound 3, half-maximal effective concentration: 500 nM
The estimate for compound 3 lay 2.0-fold (0.30 log units) below the measured number; the range from low to high includes it.
By their numbers in this assay, from the lowest: compound 2; then compounds 3 and 1 (each within the scatter of the next).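

In this assay the outer ring on an oxygen on an aromatic ring is sensitive: 2,3-dimethylphenyl in place of 4-methoxy-2-methylphenyl gives (a 2.9-fold higher number from compound 2 to compound 3 (0.47 log units; beyond the scatter)), so this change alone moves the number beyond the scatter. The link and ring pattern together matter less in the other comparison, where 2,3-dimethylphenoxy in place of 2-methylbenzyl on an aromatic carbon gives (a 1.4-fold lower number from compound 1 to compound 3 (0.15 log units; within the scatter)) and leaves the two compounds indistinguishable. Nothing available explains either step.

The compounds shown do not separate loss of the methoxy group from the different placing of the methyl groups, since both differ at once between compound 2 and compound 3. Going by these compounds, how an ethoxy group or a hydroxyl group in place of that methoxy group would read also stays open.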